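The source may report more compounds than this note shows. Statements on the series, on what has been measured and on what is new or still open speak of the compounds shown alone.

Values measured in an ADME assay on 184B5 cells (Homo sapiens) for antiproliferative activity, read by sulforhodamine B assay, with a stated time of 72 h (on this read-out lower numbers stand for stronger inhibition and higher numbers for weaker inhibition), are as follows.

Compound 1 `FC(F)(F)c1ccc(/C=C\c2cc3ccccc3nc2Cl)cc1`: 7940 nM
Compound 2 `Fc1ccc(/C=C\c2cc3ccccc3nc2Cl)cc1`: 35700 nM
Compound 3 `FC(F)(F)c1ccc(/C=C\c2cc3ccc(Cl)cc3nc2Cl)cc1`: 26400 nM

Compound 1 holds the lowest of these three numbers, so it is the strongest inhibitor of the set, and both steps away from it lie beyond the scatter. Compound 4 `COc1ccc2nc(Cl)c(/C=C\c3ccc(C(F)(F)F)cc3)cc2c1` has not been measured yet. It differs from compound 1 by methoxy in place of hydrogen on an aromatic carbon. The closest guide is chloro in place of hydrogen on an aromatic carbon, a modest step (a 3.3-fold higher number from compound 1 to compound 3 (0.52 log units; beyond the scatter)) that also adds a group to the core. The other step (a 4.5-fold higher number from compound 1 to compound 2 (0.65 log units; beyond the scatter)) replaces trifluoromethyl, a group that compound 4 keeps, so it bears on this change only loosely. Within the data shown here, no methoxy compound has been measured, so the guide is a single step with a different group. A modest rise in the number, meaning weaker inhibition, is expected (a 2.0-fold higher number from compound 1 to compound 4 (0.30 log units; within the scatter)). For compound 4 the estimated value is 16000 nM (expected range 5000 nM to 50000 nM).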

Compound 4, half-maximal inhibitory concentration: 40000 nM
Compound 4: middle estimate off by 2.5-fold (0.40 log units), on the low side; the measured number falls inside the stated range.
By their numbers in this assay, from the lowest: compound 1; then compounds 3, 2 and 4 (each within the scatter of the next).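

In this assay, methoxy on this aromatic carbon gives weaker inhibition (a 5.0-fold higher number from compound 1 to compound 4 (0.70 log units; beyond the scatter)). Chloro on the same carbon-only ring of compound 3 also raises the number, so both substituted compounds shown here lose ground, and compound 1, with hydrogen at this place, stays the strongest inhibitor of the four. No measurement here explains the rise in compound 4.

The compounds shown leave open whether any group on this carbon weakens inhibition or whether the loss belongs to methoxy itself; a hydroxyl group or an amine at the same place would help separate the two. As far as these compounds go, whether a longer chain, such as ethoxy, would widen or narrow the step also remains open.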